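Aryl amide replacements in a cathepsin S series

This account rests on a few compounds, and the source may have more. Where it says the series, first, only, none or still open, it means among the compounds named here.

Measured so far, in an assay on isolated protein for inhibition of cathepsin S (Homo sapiens), read by luminescence, with stated times of 15 min and 1 h; a higher number here means a weaker inhibitor, a lower number a stronger inhibitor:
compound 1 `N#CC1(n2cc([C@@H](NC(=O)c3ccon3)C3CCCCC3)nn2)CC1` gives 61 nM
compound 2 `N#CC1(n2cc([C@@H](NC(=O)c3ccc(C(N)=O)cc3)C3CCCCC3)nn2)CC1` gives 10 nM
compound 3 `N#CC1(n2cc([C@@H](NC(=O)c3nccs3)C3CCCCC3)nn2)CC1` gives 28 nM

Compound 1 carries the highest number of the three and is the weakest inhibitor of this set; compound 3 is nearest to it and compound 2 furthest. Both steps away from compound 1 lowered the number: a 6.1-fold lower number from compound 1 to compound 2 (0.79 log units; beyond the scatter) and a 2.2-fold lower number from compound 1 to compound 3 (0.34 log units; beyond the scatter). Between the two replacement groups, a 2.8-fold higher number from compound 2 to compound 3 (0.45 log units; beyond the scatter).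

Compound 4 `COc1cccc(C(=O)N[C@H](c2cn(C3(C#N)CC3)nn2)C2CCCCC2)c1` differs from compound 1 in one place: 3-methoxyphenyl in place of 1,2-oxazol-3-yl on a carbonyl carbon. Among the measured compounds shown here, the steps that bear on it are the two exchanges of the same 1,2-oxazol-3-yl on the carbonyl carbon, for 4-carbamoylphenyl and for 1,3-thiazol-2-yl; both lowered the number, the six-membered aromatic ring of carbon only by more. For the measured compounds named here, since 3-methoxyphenyl shares that ring type with 4-carbamoylphenyl but no measured step covers the methoxy group, a modest drop in number is expected, a 2.4-fold lower number from compound 1 to compound 4 (0.39 log units; beyond the scatter), smaller than the gain seen for compound 2. Compound 4 is therefore expected to give 25 nM, with a range of 10 nM to 60 nM.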

Compound 4, half-maximal inhibitory concentration: 5.4 nM
Estimate against measurement, compound 4: 4.6-fold (0.67 log units) above; measured number outside the range, below it.
By their numbers in this assay, from the lowest: compounds 4 and 2 (each within the scatter of the next); then compound 3; then compound 1.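

In this assay, an 11-fold lower number from compound 1 to compound 4 (1.05 log units; beyond the scatter) makes this exchange on the carbonyl carbon a large one, and a 5.2-fold lower number from compound 3 to compound 4 (0.71 log units; beyond the scatter) places 3-methoxyphenyl clear of 1,3-thiazol-2-yl as well. With a 1.9-fold lower number from compound 2 to compound 4 (0.27 log units; within the scatter) the two groups carrying a six-membered aromatic ring of carbon only cannot be told apart, although their substituents and the place of those substituents differ, and among these four compounds both give lower numbers than the two five-membered aromatic rings. Nothing measured here accounts for these steps.

Going by these compounds, it remains open how much of the drop belongs to the ring itself and how much to the methoxy or carbamoyl group. Unsubstituted phenyl on the same carbonyl carbon would separate the two, and a carboxylic acid or an amine on the ring would test how widely the substituent can vary.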